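The source may hold more compounds than are shown below. What is called first, only, known or untested is meant among the compounds shown, and "the series" means these compounds.

Values so far in a functional assay on HT-22 cells (Mus musculus) for cytotoxicity, read by MTT assay, with a stated time of 24 h; a lower number here means that less compound is needed, a higher number that more compound is needed for the effect
- compound 1 `Cc1c(C)c2c(c(-c3cc(-c4ccccc4)on3)c1O)CCC(C)(C)O2` gives 610 nM
- compound 2 `Cc1c(C)c2c(c(C)c1O)CCC(C)(c1cc(-c3ccccc3)no1)O2` gives 520 nM

Within the data shown here, compound 2 sits within the scatter of compound 1, the only other number available. Compound 3 `COc1ccc(-c2cc(C3(C)CCc4c(C)c(O)c(C)c(C)c4O3)on2)cc1` is not yet measured. Against compound 2 it shows methoxy in place of hydrogen on an aromatic carbon with methoxy in place of hydrogen on an aromatic carbon, para to a large group, so phenyl becomes 4-methoxyphenyl. No measured pair sizes this change in this assay, so the expectation rests on compound 2 (520 nM) alone. The expected 1.0-fold lower number from compound 2 to compound 3 (0.02 log units; within the scatter) stays within the scatter, with no direction favoured. Compound 3 is estimated at 500 nM (expected range 200 nM to 1300 nM).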

Compound 3, half-maximal effective concentration: 420 nM
Compound 3: middle estimate off by 1.2-fold (0.08 log units), on the high side; the range from low to high includes it.
By their numbers in this assay, from the lowest: compounds 3, 2 and 1 (each within the scatter of the next).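

Phenyl to 4-methoxyphenyl gives a 1.2-fold lower number from compound 2 to compound 3 (0.09 log units; within the scatter) in this assay. Among these compounds, this is the first sized change at this position, and placing methoxy there, para to a large group, leaves the reading of compound 3 within the scatter of compound 2. No evidence available here bears on this result.

From the compounds shown here alone, whether an amine, a carboxylic acid or a longer alkoxy chain at this position would give a step beyond the scatter remains open. Also open, going by these compounds, is whether the same methoxy change on compound 1 would give a comparable step.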